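Shared core series: trifluoromethyl in place of phenyl

A few compounds are considered here, and "the series" means these few. Any claim that something is new, unique, unknown or untested is made for them only; others in the source may bear on it.

Measured so far in a functional assay on DU-145 cells (Homo sapiens) for cytotoxicity, read by MTT assay; a lower number here means a stronger inhibitor, a higher number a weaker inhibitor:
- compound 1 `c1ccc(-c2nnc(-c3c[nH]c4ccccc34)o2)cc1`: > 1000000 nM, a limit of the assay
- compound 2 `COc1ccc(-c2nnc(-c3c[nH]c4ccccc34)o2)cc1`: > 1000000 nM, a limit of the assay
- compound 3 `COc1cc(-c2nnc(-c3c[nH]c4ccccc34)o2)ccc1O`: > 1000000 nM, a limit of the assay

Compound 1 stands at the limit of this assay, as the limit of > 1000000 nM in this assay, at which 3 of the 3 values shown sit, shows; no number is known for it. Among the measured compounds shown here, the one single-point step measured, a step that the two limits leave unreadable from compound 1 to compound 2, is therefore unreadable in size and direction. Compound 3 also sits at the limit, so its relation to compound 1 is equally unreadable.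

Compound 4 `FC(F)(F)c1nnc(-c2c[nH]c3ccccc23)o1` differs from compound 1 by trifluoromethyl in place of phenyl on an aromatic carbon. For the measured compounds named here, none of the measured steps concerns this change: the only measured step varies the phenyl itself, not its replacement, and it cannot be read. With the three compounds shown all at the limit, there is no basis to expect compound 4 to fall below it. The step from compound 1 to compound 4 in this assay is expected to be a number no higher from compound 1 to compound 4 (the limit leaves the size open), that is, none beyond the scatter. Compound 4 is estimated at 1000000 nM, in the range 300000 nM to 3000000 nM, most likely again reported only as a limit.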

Compound 4, half-maximal inhibitory concentration: > 1000000 nM
Compound 4: a limit, no number; the forecaster's own chance of this, stated with the estimate: 85%; the middle value lies on the limit itself.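

Compound 4, like compound 1, stands only at a limit in this assay, so no new step can be read between them: the limit of > 1000000 nM in this assay, at which 4 of the 4 values shown sit.

The compounds shown leave open how phenyl and trifluoromethyl compare at this place, and what number any of these compounds would have in this assay.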